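This account rests on a few compounds, and the source may have more. Where it says the series, first, only, none or still open, it means among the compounds named here.

Measured compounds in a functional assay on cells for agonist activity at Free fatty acid receptor 1 (Homo sapiens), read by calcium flux; on this read-out lower numbers stand for an effect already at smaller amounts and higher numbers for an effect only at larger amounts of compound:
- compound 1 `Cc1cccc(C)c1-c1cccc(OCn2cc(CCC(=O)O)nn2)c1`: 32200 nM
- compound 2 `CC#CC(CC(=O)O)c1ccc(OCc2cccc(-c3c(C)cccc3C)c2)s1`: 210 nM
- compound 3 `CC#C[C@@H](CC(=O)O)c1ccc(OCc2cccc(-c3c(C)cc(OCCCS(C)(=O)=O)cc3C)c2)s1`: 81 nM

Compound 3 stands lowest of the three numbers on this assay; its nearest neighbour is compound 2, whose number lies beyond the scatter above it, and compound 1 lies far above both.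

Compound 4 `CC#CC(CC(=O)O)c1ccc(OCc2cccc(-c3c(C)cc(OCCCS(C)(=O)=O)cc3C)c2)s1` is the next step from compound 3: the two compounds have the same atoms and bonds; at least one stereo element is drawn with a configuration in one of them and without one in the other: 1 of 1 stereo elements differ; a stereocentre at a saturated chain carbon is drawn R in compound 3 and without a configuration in compound 4. Among the compounds with values here, no measured pair shows this kind of change, so the step size is not anchored. Drawing the stereocentre without a configuration is expected to shift this assay toward a higher number, probably modest and possibly no further than the scatter. Compound 4 is therefore expected at 160 nM, within 60 nM to 450 nM. The expected step is a 2.0-fold higher number from compound 3 to compound 4 (0.30 log units; within the scatter).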

Compound 4, half-maximal effective concentration: 240 nM
Estimate against measurement, compound 4: 1.5-fold (0.18 log units) below, and the stated range covers the measured number.
By their numbers in this assay, from the lowest: compound 3; then compounds 2 and 4 (each within the scatter of the next); then compound 1.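

In this assay the stereocentre at the saturated chain carbon matters: drawing it without a configuration gives a 3.0-fold higher number from compound 3 to compound 4 (0.47 log units; beyond the scatter) and leaves the R drawing with the lower number. With the centre undefined in both compounds, 3-(methylsulfonyl)propoxy in place of hydrogen on an aromatic carbon gives a 1.1-fold higher number from compound 2 to compound 4 (0.06 log units; within the scatter) and so separates nothing on its own. The gap beyond the scatter therefore rests on configuration alone: the fact that one of compounds 3 and 4 is drawn with a defined configuration and the other without, at the place where they differ.

Open, as far as these compounds go, is how the S form reads. Also open, from the compounds shown here alone, is whether an amine or a carboxylic acid in place of the methylsulfonyl group would move the number.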